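Aryl for Cyclohexyl: Tolerability in HeLa Cells

A few compounds are considered here, and "the series" means these few. Any claim that something is new, unique, unknown or untested is made for them only; others in the source may bear on it.

Among the measured compounds shown here, compound 1 `COc1nc(C2CCCCC2)ccc1[C@@H](c1ccccc1)[C@@](O)(CCN(C)C)c1cccc2ccccc12` is the one member of this set that gives a number rather than a limit: in a toxicity assay on HeLa cells (Homo sapiens) for cytotoxicity (a higher number here means that more compound is tolerated, a lower number that less compound is tolerated), compound 1 gives 57.7 ug/mL. Compound 2 `COc1nc(-c2ccc(OC(F)(F)F)cc2)ccc1[C@@H](c1ccccc1)[C@@](O)(CCN(C)C)c1cccc2ccccc12` carries 4-(trifluoromethoxy)phenyl in place of cyclohexyl on an aromatic carbon. In this assay compound 2 reaches only the limit of the assay, > 64 ug/mL. Compound 3 `COc1nc(-c2ccc(C#N)cc2)ccc1[C@@H](c1ccccc1)[C@@](O)(CCN(C)C)c1cccc2ccccc12` carries 4-cyanophenyl in place of cyclohexyl on an aromatic carbon. In this assay compound 3 likewise reaches only a limit, > 64 ug/mL. The two measured steps, an at least 1.1-fold higher number from compound 1 to compound 2 (0.04 log units; that floor lies within the scatter) and an at least 1.1-fold higher number from compound 1 to compound 3 (0.04 log units; that floor lies within the scatter), are therefore floors, set by the limit of > 64 ug/mL in this assay, at which 2 of the 3 values shown sit. Between the two aryl compounds, a step that the two limits leave unreadable from compound 2 to compound 3.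

Compound 4 `COc1nc(-c2ccccc2Cl)ccc1[C@@H](c1ccccc1)[C@@](O)(CCN(C)C)c1cccc2ccccc12` differs from compound 1 by 2-chlorophenyl in place of cyclohexyl on an aromatic carbon. Both steps that bear on it, an at least 1.1-fold higher number from compound 1 to compound 2 (0.04 log units; that floor lies within the scatter) and an at least 1.1-fold higher number from compound 1 to compound 3 (0.04 log units; that floor lies within the scatter), ran to the assay limit, so the expected step of a 1.1-fold higher number from compound 1 to compound 4 (0.05 log units; within the scatter) is an upward one whose size cannot be read beyond the scatter. Compound 4 is expected to give about 64 ug/mL, between 40 ug/mL and 100 ug/mL, in this assay.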

Compound 4, half-maximal cytotoxic concentration: > 64 ug/mL
Compound 4 was reported as a limit (the forecaster's own chance of this, stated with the estimate: 60%); the middle value lies on the limit itself.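

Compound 4 shows that the aryl replacement of cyclohexyl at this place, next to the ring nitrogen, is not confined to the 4-substituted phenyl groups: 2-chlorophenyl also reaches the limit in this assay. Even so, the change gives only an at least 1.1-fold higher number from compound 1 to compound 4 (0.04 log units; that floor lies within the scatter), so no gain over compound 1 can be claimed for any of the three aryl groups. The steps among compounds 2, 3 and 4 cannot be read, because all three compounds stop at the same limit: the limit of > 64 ug/mL in this assay, at which 3 of the 4 values shown sit.

From the compounds shown here alone, how far the aryl groups truly differ from cyclohexyl or from one another therefore stays open. Also open, going by these compounds, is what an amine, a carboxylic acid or a longer chain at this place would give in this assay.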